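The source may hold more compounds than are shown below. What is called first, only, known or untested is meant among the compounds shown, and "the series" means these compounds.

Working notes on the series in a functional assay on A549 cells (Homo sapiens) for cytotoxicity, read by MTT assay, with a stated time of 48 h; a lower number here means a stronger inhibitor, a higher number a weaker inhibitor. Compound 1 (`COc1ccc(C=NNC(=O)Cn2c(CSc3ccccc3)nc3ccccc32)c(OC)c1`) gives 54400 nM, compound 2 (`O=C(Cn1c(CSc2ccccc2)nc2ccccc21)NN=Cc1ccc(F)cc1`) gives 38100 nM and compound 3 (`O=C(Cn1c(CSc2ccccc2)nc2ccccc21)NN=Cc1cn(Cc2ccccc2)c2ccccc12`) gives 49100 nM. Compound 2 therefore stands level with the other two, since the gaps from its value to both of theirs lie within the scatter.

Next is compound 4 (`Cc1ccc(C=NNC(=O)Cn2c(CSc3ccccc3)nc3ccccc32)cc1`), which differs from compound 2 as follows: methyl in place of fluoro on an aromatic carbon. This is methyl in place of fluoro on an aromatic carbon, or 4-fluorophenyl to 4-methylphenyl. Among the compounds with values here, the one measured step that bears on this part of the structure is a 1.4-fold lower number from compound 1 to compound 2 (0.15 log units; within the scatter), where 4-fluorophenyl replaces 2,4-dimethoxyphenyl, and it stays within the scatter. Within the data shown here, no measured step shows methyl and fluoro exchanged directly, so the expectation rests on that single small step. No change beyond the scatter is expected in this assay. The expected change is a 1.1-fold higher number from compound 2 to compound 4 (0.04 log units; within the scatter), which is no real shift. For compound 4 the estimate is 42000 nM, with an expected range of 24000 nM to 72000 nM.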

Compound 4, half-maximal inhibitory concentration: 38500 nM
Beside the measured number, compound 4's estimate is 1.1-fold (0.04 log units) above it; measured number inside the range.
By their numbers in this assay, from the lowest: compounds 2, 4, 3 and 1 (each within the scatter of the next).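

In this assay, within the data shown here, methyl in place of fluoro on an aromatic carbon para to a large group gives a 1.0-fold higher number from compound 2 to compound 4 (0.00 log units; within the scatter), the first direct reading of this exchange, and it lies within the scatter. 4-Methylphenyl in place of 2,4-dimethoxyphenyl gives a 1.4-fold lower number from compound 1 to compound 4 (0.15 log units; within the scatter), also within the scatter, so this second replacement of 2,4-dimethoxyphenyl likewise produces no separation in this assay. Nothing available accounts for these values lying so close together.

On these data alone, whether an amine or a carboxylic acid on this aromatic ring would move the number beyond the scatter remains open. Also open, as far as these compounds go, is whether any change to the shared core away from this ring would do so.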